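The source may report more compounds than this note shows. Statements on the series, on what has been measured and on what is new or still open speak of the compounds shown alone.

Measured so far in an ADME assay on MDCK cells (Canis lupus familiaris) for cytotoxicity; a higher number here means that more compound is tolerated, a lower number that less compound is tolerated:

- Compound 1 `CC(=O)Nc1ccc2oc(-c3ccnc(C(=O)N4CCN(C(c5nnn(C)n5)c5ccccc5F)CC4)c3)nc2c1` gives > 50000 nM, which is a limit.
- Compound 2 `CC(=O)Nc1ccc2oc(-c3ccnc(C(=O)N4CCN(C(c5ccc(Br)cc5)c5nnn(C)n5)CC4)c3)nc2c1` gives > 50000 nM, which is a limit.

Compound 2 therefore stands on a limit, and there is no number to start from. Compound 3 `COc1ccc(C(c2nnn(C)n2)N2CCN(C(=O)c3cc(-c4nc5cc(NC(C)=O)ccc5o4)ccn3)CC2)cc1` differs from compound 2 as follows: methoxy in place of bromo on an aromatic carbon. In words, it carries methoxy in place of bromo on an aromatic carbon, para to a large group, so 4-bromophenyl becomes 4-methoxyphenyl.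

Among the measured compounds shown here, the one measured step touching the same phenyl group is a step that the two limits leave unreadable from compound 1 to compound 2, with 4-bromophenyl in place of 2-fluorophenyl, and it offers no size to carry over. Compound 1 and compound 2 both rest on the limit of > 50000 nM in this assay, at which 2 of the 2 values shown sit, and neither shows any response to a change in that group. No step beyond the scatter is therefore expected in this assay, in either direction. The expected step is a number no higher from compound 2 to compound 3 (the limit leaves the size open) and a further limit is the likeliest report. The estimate for compound 3 is 50000 nM, with an expected range from 30000 nM to 100000 nM.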

Compound 3, half-maximal cytotoxic concentration: > 50000 nM
Compound 3: only a limit was reported (the forecaster's own chance of this, stated with the estimate: 85%); the middle value lies on the limit itself.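

No new step can be read in this assay from compound 1, compound 2 and compound 3, as all three rest on one limit: the limit of > 50000 nM in this assay, at which 3 of the 3 values shown sit.

The compounds shown leave open where the true values of these three lie, and whether any of the changes on the phenyl group alters tolerance in this series.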